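The source may report more compounds than this note shows. Statements on the series, on what has been measured and on what is new or still open speak of the compounds shown alone.

Measured so far in a functional assay on HepG2 cells (Homo sapiens) for cytotoxicity, with a stated time of 72 h; on this read-out lower numbers stand for an effect already at smaller amounts and higher numbers for an effect only at larger amounts of compound:
- Compound 1 `C=C[C@@](C)(/C=C/c1ccc(O)cc1)CCC=O`: > 52000 nM, a limit
- Compound 2 `C=C[C@@](C)(/C=C/c1ccc(O)cc1)CCCO`: > 52000 nM, a limit
- Compound 3 `C=C[C@@](C)(/C=C/c1ccc(O)cc1)CC/C=C/C(=O)c1ccccc1`: > 52000 nM, a limit

Compound 2 has no exact number, only the limit > 52000 nM. It shares this position with the other measured compounds: the limit of > 52000 nM in this assay, at which 3 of the 3 values shown sit. Compound 4 `C=C[C@@](C)(/C=C/c1ccc(O)cc1)CC/C=C(C)/C=N/N`, not yet measured, replaces the hydroxymethyl of compound 2 with a larger group that has no common name: a group of 6 heavy atoms (4 carbon, 2 nitrogen; no ring) in place of a group of 2 heavy atoms (1 carbon, 1 oxygen; no ring), on a saturated chain carbon, three bonds along the chain from two double-bonded chain carbons.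

One measured step involves this same place on the chain: a step that the two limits leave unreadable from compound 1 to compound 2. It offers no size to carry over. Compound 3 also carries a larger group at this place, and compound 3 is likewise only a limit, > 52000 nM.

With no measured number in the series, no clear direction can be expected in this assay. The expected step, a number no higher from compound 2 to compound 4 (the limit leaves the size open), is only a rough estimate. For compound 4 the estimated value is 52000 nM, with an expected range of 20000 nM to 100000 nM. A further limit is the likeliest report.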

Compound 4, half-maximal effective concentration: > 52000 nM
Compound 4 ended at the assay's limit; the forecaster's own chance of this, stated with the estimate: 65%; the middle value lies on the limit itself.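

In this assay compound 4 gives > 52000 nM, a limit and not a number. The steps from compound 1 and compound 2 to compound 4 therefore cannot be read, because every value is the same limit: the limit of > 52000 nM in this assay, at which 4 of the 4 values shown sit.

The compounds shown leave open whether changing this chain end alters the effect on these cells at all.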